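Swapping the benzyl group in a sulfonylurea orexin ligand

This account rests on a few compounds, and the source may have more. Where it says the series, first, only, none or still open, it means among the compounds named here.

Measured compounds:
compound 1, `COc1cc(F)c(CN2C(=O)N(c3ccc(OC)c(OC)c3)S(=O)(=O)c3ccccc32)c(Cl)c1`: 0.1 nM
compound 2, `COc1cc(F)c(CN2C(=O)N(c3cc(OC)nc(OC)c3)S(=O)(=O)c3ccccc32)c(F)c1`: 0.251 nM
compound 3, `COc1cc(F)c(CN2C(=O)N(c3ccc(OC)c(OC)n3)S(=O)(=O)c3ccccc32)c(F)c1`: 0.2 nM

In an assay on HEK293 cells for displacement of a labelled ligand from Orexin receptor type 2 (Homo sapiens), read by scintillation counting, with a stated time of 90 min (a higher number here means a weaker inhibitor, a lower number a stronger inhibitor), compound 1 gives the lowest of the three numbers; compound 3 stands within the scatter of it, compound 2 beyond it. Compound 4, `COc1ccc(N2C(=O)N(Cc3ccc(F)cc3Cl)c3ccccc3S2(=O)=O)cc1OC`, is not yet measured. It differs from compound 1 in one place: 2-chloro-4-fluorophenyl in place of 2-chloro-6-fluoro-4-methoxyphenyl on a saturated chain carbon bound to an amide-type nitrogen in a ring. For the measured compounds named here, no measured step touches this part of the molecule; the only step known, a 1.3-fold lower number from compound 2 to compound 3 (0.10 log units; within the scatter), concerns the other aromatic ring and cannot guide this change. Since a methoxy group is lost and the fluorine moves, some weakening is plausible, but the size is open. Compound 4 is therefore expected to give 0.5 nM, between 0.1 nM and 3 nM, a step of a 5.0-fold higher number from compound 1 to compound 4 (0.70 log units; beyond the scatter).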

Compound 4, inhibition constant: 25.1 nM
Estimate against measurement, compound 4: 50-fold (1.70 log units) below, and the stated range ends below it.
By their numbers in this assay, from the lowest: compounds 1, 3 and 2 (each within the scatter of the next, the first and the last beyond it); then compound 4.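

In this assay, the benzyl group turns out to be a highly sensitive part of the molecule, something the earlier step on the other aromatic ring could not reveal: 2-chloro-4-fluorophenyl in place of 2-chloro-6-fluoro-4-methoxyphenyl gives a 250-fold higher number from compound 1 to compound 4 (2.40 log units; beyond the scatter) for this single change. That change removes the methoxy group and also shifts the fluorine, so the two differences cannot be separated here. Nothing available explains the size of this step. As far as these compounds go, it remains open which of the two differences matters more, and whether an ethoxy group or an amine in place of the methoxy group would preserve the low number of compound 1.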